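A few compounds are considered here, and "the series" means these few. Any claim that something is new, unique, unknown or untested is made for them only; others in the source may bear on it.

Working notes on a small ester series built on one shared core. Compound 1 `CC1=C(C(=O)OC2CCCCC2)C(c2ccoc2)NC(=O)N1` carries a cyclohexyl ester and a furan-3-yl group; in an assay on membranes from HeLa cells for displacement of a labelled ligand from adenosine receptor A3 (Homo sapiens), read by scintillation counting, with a stated time of 180 min, tested at 1 uM (on this read-out lower numbers stand for less inhibition and higher numbers for more inhibition at the one concentration tested (going by the name of the read-out)), compound 1 gives 1%. Compound 2 `CC1=C(C(=O)OCC2CC2)C(c2ccoc2)NC(=O)N1` differs from compound 1 by cyclopropylmethyl in place of cyclohexyl on an oxygen next to a carbonyl group; in this assay compound 2 gives 3%, and the step is a number 2 percentage points higher from compound 1 to compound 2 (within the scatter). Compound 3 `CC1=C(C(=O)OC2CCCCC2)C(c2cccs2)NC(=O)N1` differs from compound 1 in the core, by thiophen-2-yl in place of furan-3-yl on a saturated ring carbon; in this assay compound 3 gives 1%, the step being no change at the digits printed from compound 1 to compound 3 (within the scatter). Compound 1 and compound 3 stand level, and all three measured values lie within the scatter of one another, so no order among them can be read; the three compounds show essentially no inhibition at the single concentration tested.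

Compound 4 `CC1=C(C(=O)OCC2CC2)C(c2cccs2)NC(=O)N1` has not yet been measured. It differs from compound 3 by cyclopropylmethyl in place of cyclohexyl on an oxygen next to a carbonyl group; this is the same change as that from compound 1 to compound 2, made here on the core of compound 3 rather than that of compound 1. Within the data shown here, since the earlier instance of the change produced only a number 2 percentage points higher from compound 1 to compound 2 (within the scatter), and since the core swap between compound 1 and compound 3 gave no change at the digits printed from compound 1 to compound 3 (within the scatter), nothing among the measured compounds points to a move out of the flat region. The step from compound 3 to compound 4 in this assay is therefore expected to be a number 2 percentage points higher from compound 3 to compound 4 (within the scatter), resting on the step of a number 2 percentage points higher from compound 1 to compound 2 (within the scatter) seen for compound 1 and compound 2. For compound 4 in this assay the estimate is 3%, with the expected range running from 0% to 12%.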

Compound 4, a percentage reported as inhibition, at one concentration (the size of the read-out at that concentration, not a potency): 1%
Compound 4: the middle estimate sits 2 percentage points above what was measured; the range from low to high includes it.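

In this assay, the ester change on the core of compound 3 gives no change at the digits printed from compound 3 to compound 4 (within the scatter), and the swap of thiophen-2-yl for furan-3-yl with the cyclopropylmethyl ester in place gives a number 2 percentage points lower from compound 2 to compound 4 (within the scatter). The ester change carries from one core to the other with no gap that can be told from the scatter: the same change on two cores in this assay, a number 2 percentage points higher (within the scatter) from compound 1 to compound 2 and no change at the digits printed (within the scatter) from compound 3 to compound 4, 2 percentage points apart, within the scatter of two such steps
The ring swap reads the same way, but with all four compounds showing essentially no inhibition, this agreement shows only that neither change lifts the read-out on these cores, not that a change with a clear effect would carry over or that the two changes add up: the same change on two cores in this assay, no change at the digits printed (within the scatter) from compound 1 to compound 3 and a number 2 percentage points lower (within the scatter) from compound 2 to compound 4, 2 percentage points apart, within the scatter of two such steps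

The compounds shown cover only cyclohexyl and cyclopropylmethyl on the ester oxygen and furan-3-yl and thiophen-2-yl on the saturated ring carbon, so it stays open whether anything on the shared core gives a clear signal in this assay. A longer chain or a benzyl group on the ester oxygen, a carboxylic acid or an amide in place of the ester, or a phenyl ring bearing an amine in place of the furan-3-yl group could each be read against this flat set.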